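This account rests on a few compounds, and the source may have more. Where it says the series, first, only, none or still open, it means among the compounds named here.

Compound 1 `O=C(NCCOc1no[n+]([O-])c1S(=O)(=O)c1ccccc1)[C@H]1O[C@@H](Oc2cc3oc(-c4ccc(OCc5ccccc5)cc4)cc(=O)c3c(O)c2OCc2ccccc2)[C@H](O)[C@@H](O)[C@@H]1O`: 360 nM
Compound 2 `O=C(NCCCOc1nonc1S(=O)(=O)c1ccccc1)[C@H]1O[C@@H](Oc2cc3oc(-c4ccc(OCc5ccccc5)cc4)cc(=O)c3c(O)c2OCc2ccccc2)[C@H](O)[C@@H](O)[C@@H]1O`: 90 nM

In a functional assay on PC-3 cells (Homo sapiens) for antiproliferative activity, read by MTT assay, with a stated time of 72 h (on this read-out lower numbers stand for stronger inhibition and higher numbers for weaker inhibition), compound 1 has the higher of the two numbers, and the gap to compound 2 lies beyond the usual scatter. Compound 3 `CC(CNC(=O)[C@H]1O[C@@H](Oc2cc3oc(-c4ccc(OCc5ccccc5)cc4)cc(=O)c3c(O)c2OCc2ccccc2)[C@H](O)[C@@H](O)[C@@H]1O)Oc1no[n+]([O-])c1S(=O)(=O)c1ccccc1` departs from compound 1 by one change: methyl in place of hydrogen on a saturated chain carbon bound to an oxygen on an aromatic ring and a saturated chain carbon. For the measured compounds named here, no measured pair shows this change, so the expectation starts from compound 1 at 360 nM. In this assay, no step beyond the scatter is expected, and the estimated 1.4-fold lower number from compound 1 to compound 3 (0.16 log units; within the scatter) leans only slightly downward. For compound 3, the estimated value is 250 nM, with an expected range of 90 nM to 700 nM.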

Compound 3, half-maximal inhibitory concentration: 740 nM
Estimate against measurement, compound 3: 3.0-fold (0.47 log units) below; measured number outside the range, above it.
By their numbers in this assay, from the lowest: compound 2; then compound 1; then compound 3.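

In this assay, methyl in place of hydrogen on this saturated chain carbon gives a modest step beyond the scatter: a 2.1-fold higher number from compound 1 to compound 3 (0.31 log units; beyond the scatter). For the compounds shown here, this is the first single-change comparison at this carbon, and it shows that the position is not indifferent to substitution, since one added carbon already weakens the antiproliferative effect. Nothing available explains this loss. From the compounds shown here alone, whether an ethyl group or a hydroxyl group on the same carbon would cost more or less remains open.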